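The compounds below may be only part of what the source reports. "The series", "measured", "known", "first", "only" and "open" are said of these compounds alone.

Measured compounds and their values in a functional assay on SK-OV-3 cells (Homo sapiens) for cytotoxicity, read by MTT assay, with a stated time of 48 h; on this read-out lower numbers stand for stronger inhibition and higher numbers for weaker inhibition:
compound 1, `O=C(/C=C/c1ccc2c(c1)B(O)OC2)c1ccc(Cl)cc1`: 3700 nM
compound 2, `Cc1ccc(C(=O)/C=C/c2ccc3c(c2)B(O)OC3)cc1`: 3700 nM
compound 3, `Nc1ccc(C(=O)/C=C/c2ccc3c(c2)B(O)OC3)cc1`: 20200 nM

Compound 3 stands highest of the three numbers in this assay. Its two neighbours lie well apart from it: the step of a 5.5-fold higher number from compound 1 to compound 3 (0.74 log units; beyond the scatter) and the step of a 5.5-fold higher number from compound 2 to compound 3 (0.74 log units; beyond the scatter) are both beyond the scatter, so compound 3 is the weakest of the three measured compounds. Between compound 1 and compound 2 the step of no change at the digits printed from compound 1 to compound 2 (within the scatter) shows no separation.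

Compound 4, `Nc1cccc(C(=O)/C=C/c2ccc3c(c2)B(O)OC3)c1`, has not yet been measured. It differs from compound 3 by 3-aminophenyl in place of 4-aminophenyl on a carbonyl carbon. For the measured compounds named here, no measured step bears directly on this change: the two steps that reach compound 3 both swap a different group for the amino group at the same position, and no pair among the measured compounds moves a group from one position of that ring to another. The account therefore has nothing to draw on for the direction of this step, and the plain expectation is no shift beyond the scatter, with a wide range to allow for the unknown.

Compound 4 is accordingly estimated at 18000 nM in this assay, with a range from 6000 nM to 50000 nM; the estimated step is a 1.1-fold lower number from compound 3 to compound 4 (0.05 log units; within the scatter).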

Compound 4, half-maximal inhibitory concentration: 7400 nM
For compound 4 the middle estimate is 2.4-fold (0.39 log units) above the measured one, within the range that was stated.
By their numbers in this assay, from the lowest: compounds 1, 2 and 4 (each within the scatter of the next); then compound 3.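

In this assay, for the compounds shown here, the change from 4-aminophenyl to 3-aminophenyl on the carbonyl carbon gives a 2.7-fold lower number from compound 3 to compound 4 (0.44 log units; beyond the scatter) and is beyond the scatter, so with the same atoms joined differently, where the amino group sits on this ring matters, something no earlier pair could show. The steps of a 2.0-fold higher number from compound 2 to compound 4 (0.30 log units; within the scatter) and a 2.0-fold higher number from compound 1 to compound 4 (0.30 log units; within the scatter) both lie within the scatter, so compound 4 cannot be told apart from the compounds carrying 4-methylphenyl and 4-chlorophenyl. The higher number seen so far therefore does not go with the amino group as such but only with 4-aminophenyl, in compound 3 alone. Nothing shown here explains why the placing of the amino group counts.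

Going by these compounds, it remains open whether methyl or chloro would respond to the same move as the amino group does, since this shift is seen for the amino group only. Also open, on these data alone, is how a hydroxyl group or a carboxylic acid would read in this assay in the place that the amino group holds in compound 4.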